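Adding a bromo group to compound 3

This account rests on a few compounds, and the source may have more. Where it says the series, first, only, none or still open, it means among the compounds named here.

Measured in a functional assay on SW480 cells (Homo sapiens) for antiproliferative activity, read by MTT assay, with a stated time of 48 h; a lower number here means a stronger inhibitor, a higher number a weaker inhibitor:
Compound 1 `CCCCCC(CCO)n1c(Br)nc2c(Cl)ncnc21`: 23800 nM
Compound 2 `CCCCCCC(CCO)n1c(Br)nc2c(Cl)ncnc21`: 14100 nM
Compound 3 `CCCCCCCCCC(CCO)n1cnc2c(Cl)ncnc21`: 1150 nM
Compound 4 `CCCCCCCCCC(CCO)n1c(Br)nc2c(Cl)ncnc21`: not yet measured

Compound 3 has the lowest number of the three, and its gaps to compound 1 and compound 2 lie beyond the scatter. Compound 4 differs from it by one change: bromo in place of hydrogen on an aromatic carbon. In words, this is bromo in place of hydrogen on an aromatic carbon. Among the compounds with values here, no measured pair shows this change alone. Within the data shown here, the only measured step, a 1.7-fold lower number from compound 1 to compound 2 (0.23 log units; within the scatter), concerns chain length and lies within the scatter, so it offers little guidance. Compound 4 shares the bromo with compound 2 at 14100 nM and the longer chain with compound 3 at 1150 nM, so a value between these two is expected. The estimated move in this assay is a 3.0-fold higher number from compound 3 to compound 4 (0.48 log units; beyond the scatter). Compound 4 is expected at about 3500 nM, with an estimated range of 1100 nM to 11000 nM.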

Compound 4, half-maximal inhibitory concentration: 25000 nM
Estimate against measurement, compound 4: 7.1-fold (0.85 log units) below; the measured number lies above the stated range.
By their numbers in this assay, from the lowest: compound 3; then compounds 2, 1 and 4 (each within the scatter of the next).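

In this assay, the step of a 22-fold higher number from compound 3 to compound 4 (1.34 log units; beyond the scatter) shows that bromo in place of hydrogen on this aromatic carbon, between two ring nitrogen atoms, carries a large penalty on the long chain. Once the bromo is present, chain length no longer separates the compounds: a 1.8-fold higher number from compound 2 to compound 4 (0.25 log units; within the scatter) and a 1.1-fold higher number from compound 1 to compound 4 (0.02 log units; within the scatter) both lie within the scatter. Nothing available explains this loss.

Going by these compounds, what a methyl or an amine would do at this position remains open, as does whether a longer chain would change the picture.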